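The source may report more compounds than this note shows. Statements on the series, on what has been measured and on what is new or still open speak of the compounds shown alone.

Compound 1 `NC(=O)c1c(NC(=O)c2ccc(C(F)(F)F)cc2)sc2c1CCN(Cc1ccc(Cl)cc1)C2` gives > 50000 nM in a functional assay on HeLa cells (Homo sapiens) for antiproliferative activity, with a stated time of 24 h (on this read-out lower numbers stand for stronger inhibition and higher numbers for weaker inhibition), a limit of the assay. Compound 2 `NC(=O)c1c(NC(=O)c2ccc(C(F)(F)F)cc2)sc2c1CCN(Cc1c(Cl)cccc1Cl)C2` gives > 50000 nM in this assay, again a limit. Compound 3 `NC(=O)c1c(NC(=O)c2ccc(C(F)(F)F)cc2)sc2c1CCN(Cc1ccc(Cl)cc1Cl)C2` gives > 50000 nM in this assay, also a limit.

Compound 2 therefore stands at a limit, and the two other values known in this assay are limits as well; all three sit at the limit of > 50000 nM in this assay, at which 3 of the 3 values shown sit. The steps among them, a step that the two limits leave unreadable from compound 1 to compound 2, a step that the two limits leave unreadable from compound 1 to compound 3 and a step that the two limits leave unreadable from compound 2 to compound 3, cannot be read in size or direction.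

Compound 4 `NC(=O)c1c(NC(=O)c2cccc([N+](=O)[O-])c2)sc2c1CCN(Cc1c(Cl)cccc1Cl)C2` differs from compound 2 by 3-nitrophenyl in place of 4-(trifluoromethyl)phenyl on a carbonyl carbon. Going by the values given here, no measured step touches the group on the carbonyl carbon; the steps that involve compound 2 all concern the group on the ring nitrogen, and each is unreadable. There is thus no basis for expecting a step in this assay of any particular size, and the most likely outcome is another limit. Compound 4 is expected to give 50000 nM, in the range 15000 nM to 200000 nM. The expected step is a number no higher from compound 2 to compound 4 (the limit leaves the size open).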

Compound 4, half-maximal inhibitory concentration: 46100 nM
The estimate for compound 4 lay 1.1-fold (0.04 log units) above the measured number, and the stated range covers the measured number.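

With the group on the ring nitrogen held fixed, replacing 4-(trifluoromethyl)phenyl with 3-nitrophenyl on the carbonyl carbon brings this assay to a readable number, and the change is an at least 1.0-fold lower number from compound 2 to compound 4 (0.03 log units; that floor lies within the scatter). Going by these compounds alone, the steps among compound 1, compound 2 and compound 3 cannot be read and touch only the group on the ring nitrogen, whereas this one gives the first sign that the group on the carbonyl carbon can move the read-out off the limit, though its true size remains unknown. Of the compounds shown, compound 4 alone carries a number rather than a limit: the limit of > 50000 nM in this assay, at which 3 of the 4 values shown sit.

Going by these compounds, it remains open whether 3-nitrophenyl would also give a number with 4-chlorophenyl or 2,4-dichlorophenyl on the ring nitrogen. On these data alone, it also remains open how a phenyl ring bearing an amine or a carboxylic acid in place of the nitro group would read on the carbonyl carbon.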